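A few compounds are considered here, and "the series" means these few. Any claim that something is new, unique, unknown or untested is made for them only; others in the source may bear on it.

In a functional assay on HeLa cells (Homo sapiens) for antiproliferative activity, read by sulforhodamine B assay, with a stated time of 48 h (a lower number here means a stronger inhibitor, a higher number a weaker inhibitor), compound 1 `COc1cc(OC)c2sc(-c3ccc(N/C=C\C(=O)c4ccc(OC)c(O)c4)c(C)c3)nc2c1` gives 16100 nM, compound 2 `COc1cc(OC)c2sc(-c3ccc(N/C=C\C(=O)c4ccc(OC)c(O)c4)cc3)nc2c1` gives 12100 nM, and compound 3 `COc1ccc2nc(-c3ccc(N/C=C\C(=O)c4cc(OC)c(OC)c(OC)c4)c(C)c3)sc2c1` gives 16100 nM. Compound 3 stands level with compound 1 at the digits shown and within the scatter of compound 2, so the numbers do not separate these three compounds.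

The open step leads to compound 4 `COc1ccc2nc(-c3ccc(N/C=C\C(=O)c4cc(OC)c(OC)c(OC)c4)cc3)sc2c1`: hydrogen in place of methyl on an aromatic carbon. This is hydrogen in place of methyl on an aromatic carbon, ortho to a large group and meta to a 6-methoxy-1,3-benzothiazol-2-yl group.

Among the measured compounds shown here, one measured step bears on it, the same exchange in another pair of the series: a 1.3-fold lower number from compound 1 to compound 2 (0.12 log units; within the scatter). That single step lies within the scatter, so no step beyond the scatter is expected in this assay. The expected step is a 1.3-fold lower number from compound 3 to compound 4 (0.11 log units; within the scatter), a small one that stays within the scatter. For compound 4 the estimated value is 12500 nM, with an expected range of 6500 nM to 24000 nM.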

Compound 4, half-maximal inhibitory concentration: 14100 nM
Estimate against measurement, compound 4: 1.1-fold (0.05 log units) below; low and high end bracket the measured number.
By their numbers in this assay, from the lowest: compounds 2, 4, 1 and 3 (each within the scatter of the next).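

Hydrogen in place of methyl on this aromatic carbon, ortho to a large group and meta to a 6-methoxy-1,3-benzothiazol-2-yl group, now has a second reading in this assay: a 1.1-fold lower number from compound 3 to compound 4 (0.06 log units; within the scatter). Among the compounds shown here, the single earlier step could not show whether the exchange reads alike on a second core, and the two steps now agree: the same change on two cores in this assay, a 1.3-fold lower number (0.12 log units; within the scatter) from compound 1 to compound 2 and a 1.1-fold lower number (0.06 log units; within the scatter) from compound 3 to compound 4, 1.2-fold (0.07 log units) apart, within the scatter of two such steps On these two cores, the numbers do not separate methyl from hydrogen at this position.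

The compounds shown leave open what an amine, a carboxylic acid or a longer chain such as propyl would do on this carbon. On these data alone, compound 1 and compound 3 differ in more than one place, so the effect of each other difference between the two cores also stays open.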